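Swapping bromo for methoxy on the pendant ring

The source may hold more compounds than are shown below. What is called first, only, known or untested is meant among the compounds shown, and "the series" means these compounds.

Of the compounds shown here, three built on one shared core have been tested in a functional assay on the whole organism (strain Wistar) with Rattus norvegicus as the target, with a stated time of 15 days, at a dose of 3 mg/kg by the oral route; on this read-out higher numbers stand for a stronger effect at the one dose given and lower numbers for a weaker effect. Compound 1 `O=C1NC(=O)/C(=C/c2ccc(OCCSc3nnc(-c4ccccc4)[nH]3)cc2)S1` gives 18.6%. Compound 2 `O=C1NC(=O)/C(=C/c2ccc(OCCSc3nnc(-c4ccccc4[N+](=O)[O-])[nH]3)cc2)S1` gives 19.8%, and the difference a number 1.2 percentage points higher from compound 1 to compound 2 (within the scatter) lies within the usual scatter. Compound 3 `O=C1NC(=O)/C(=C/c2ccc(OCCSc3nnc(-c4ccc(Br)cc4)[nH]3)cc2)S1` gives 28.4%, the highest of the three numbers, yet the differences a number 8.6 percentage points higher from compound 2 to compound 3 (within the scatter) and a number 9.8 percentage points higher from compound 1 to compound 3 (within the scatter) both fall within the scatter, so none of the three can be ranked against another.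

Compound 4 `COc1ccc(-c2nnc(SCCOc3ccc(/C=C4\SC(=O)NC4=O)cc3)[nH]2)cc1` differs from compound 3 in one place: methoxy in place of bromo on an aromatic carbon. For the measured compounds named here, the only measured step that bears on this is the one that introduced the bromo group, a number 9.8 percentage points higher from compound 1 to compound 3 (within the scatter), and it stayed within the scatter. Going by the values given here, no measured compound carries a methoxy group, so its effect here is unknown. Removing the bromo group is therefore expected to produce no change beyond the scatter. Compound 4 is estimated at 23%, with a range from 12% to 34%. The step this estimate implies, a number 5.4 percentage points lower from compound 3 to compound 4 (within the scatter), is expected to remain within the scatter.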

Compound 4, a percentage reported as activity, at one dose (the size of the read-out at that dose, not a potency): 43.1%
The estimate for compound 4 lay 20.1 percentage points below the measured number; the measured number lies above the stated range.
By their numbers in this assay, from the lowest: compounds 1, 2 and 3 (each within the scatter of the next); then compound 4.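

In this assay, for the compounds shown here, the group at this place, para to a large group on the pendant ring, now makes a readable difference: methoxy in place of bromo gives a number 14.7 percentage points higher from compound 3 to compound 4 (beyond the scatter) and so leaves the scatter, which no step among the earlier compounds did. Methoxy also stands clear of the other two compounds, with methoxy in place of hydrogen giving a number 24.5 percentage points higher from compound 1 to compound 4 (beyond the scatter) and 4-methoxyphenyl in place of 2-nitrophenyl giving a number 23.3 percentage points higher from compound 2 to compound 4 (beyond the scatter), so compound 4 has the highest number of the four. Nothing available explains why this swap raises the number.

Going by these compounds, it remains open whether the oxygen alone is enough or the methyl on it also matters, which a hydroxy group or a longer ethoxy group at the same place could test. On these data alone, it is also open whether methoxy would give a similar number elsewhere on the ring.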